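The compounds below may be only part of what the source reports. "The series", "measured", "known", "first", "only" and "open" are said of these compounds alone.

Measured compounds in a functional assay on Jurkat cells (Homo sapiens) for antiproliferative activity, read by MTT assay, with a stated time of 48 h; a lower number here means a stronger inhibitor, a higher number a weaker inhibitor: compound 1 `COC(=O)/C=C/c1ccc2c(c1)C(=O)C(=O)N2` gives 200 nM; compound 2 `COC(=O)/C=C/c1ccc2c(c1)C(=O)C(=O)N2C` gives 250 nM; compound 3 `COC(=O)/C=C/c1ccc2c(c1)C(=O)C(=O)N2Cc1ccc(C#N)cc1` gives 80 nM.

Compound 3 has the lowest number of the three, beyond the scatter from both compound 1 and compound 2. Compound 4 `COC(=O)/C=C/c1ccc2c(c1)C(=O)C(=O)N2Cc1ccc(C)cc1` differs from compound 3 by methyl in place of cyano on an aromatic carbon. Among the compounds with values here, no measured step changes a substituent on the benzyl ring. The step of a 3.1-fold lower number from compound 2 to compound 3 (0.49 log units; beyond the scatter) shows what the whole 4-cyanophenyl adds on the nitrogen, while a 1.3-fold higher number from compound 1 to compound 2 (0.10 log units; within the scatter) shows the bare methyl on that nitrogen is neutral. Neither separates the cyano from the rest of the benzyl. Compound 4 is therefore expected to stay near compound 3, with a step of a 1.5-fold higher number from compound 3 to compound 4 (0.18 log units; within the scatter) at most, possibly slightly weaker. The estimate for compound 4 is 120 nM, range 50 nM to 300 nM.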

Compound 4, half-maximal inhibitory concentration: 50 nM
Estimate against measurement, compound 4: 2.4-fold (0.38 log units) above, within the range that was stated.
By their numbers in this assay, from the lowest: compounds 4 and 3 (each within the scatter of the next); then compounds 1 and 2 (each within the scatter of the next).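

In this assay methyl in place of cyano on this aromatic carbon stays within the scatter (a 1.6-fold lower number from compound 3 to compound 4 (0.20 log units; within the scatter)), so the nitrile is not required to keep the lower number seen with compound 3. The 4-methylbenzyl group on the ring nitrogen still gives steps beyond the scatter (a 5.0-fold lower number from compound 2 to compound 4 (0.70 log units; beyond the scatter); a 4.0-fold lower number from compound 1 to compound 4 (0.60 log units; beyond the scatter)), though both remain modest. Nothing available explains why this change is tolerated.

Open, from the compounds shown here alone, is whether an amine or a carboxylic acid on this aromatic carbon would stay in the same range. Also open, going by these compounds, is how a longer chain on the ring nitrogen would compare.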